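A few compounds are considered here, and "the series" means these few. Any claim that something is new, unique, unknown or untested is made for them only; others in the source may bear on it.

Compound 1 `COc1cc(Nc2ncc(C(F)(F)F)c(N3Cc4cccc(N(C)S(C)(=O)=O)c4C3)n2)c(OC)cc1Cl` and compound 2 `CN(c1cccc2c1CN(c1nc(Nc3ccc(C(F)(F)F)cc3)ncc1C(F)(F)F)C2)S(C)(=O)=O` share one core and differ only in the aryl group carried on a nitrogen on an aromatic ring. In an assay on Sf9 cells for inhibition of tyrosine-protein kinase receptor UFO (Homo sapiens), read by luminescence and ADP-Glo (on this read-out higher numbers stand for weaker inhibition and lower numbers for stronger inhibition), compound 1 gives only a limit of the assay, > 20000 nM. In this assay compound 2 likewise gives only a limit, > 20000 nM. The step that the two limits leave unreadable from compound 1 to compound 2 cannot be read, since (the limit of > 20000 nM in this assay, at which 2 of the 2 values shown sit). Compound 2 thus stands at the limit, with no number of its own on the scale shown. Compound 3 `Cc1cc(C)cc(Nc2ncc(C(F)(F)F)c(N3Cc4cccc(N(C)S(C)(=O)=O)c4C3)n2)c1` is the analogue still to be measured, differing from compound 2 by 3,5-dimethylphenyl in place of 4-(trifluoromethyl)phenyl on a nitrogen on an aromatic ring. Among the measured compounds shown here, the only measured step is of unreadable size, so no direction for this assay can be drawn from it, and the plain expectation is that compound 3 also returns a limit. Compound 3 is therefore estimated at 25000 nM, with a range from 10000 nM to 60000 nM. The expected step is a step that the limit leaves unreadable from compound 2 to compound 3, which amounts to no change beyond the scatter.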

Compound 3, half-maximal inhibitory concentration: > 20000 nM
Compound 3: only a limit was reported; the forecaster's own chance of this, stated with the estimate: 80%; the middle value does not contradict the limit.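

Among the compounds shown here, no step among compound 1, compound 2 and compound 3 can be read in this assay, as each gives only a limit of the assay: the limit of > 20000 nM in this assay, at which 3 of the 3 values shown sit.

The compounds shown leave open how these three aryl groups rank against one another, and whether any of them gives a measurable inhibition on this scale.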